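The compounds below may be only part of what the source reports. "The series", "measured", "known", "first", "only" and "open" are said of these compounds alone.

Measured compounds:
Compound 1, `CC[C@@H](Nc1c(Nc2cccc(C(=O)N(C)C)c2O)c(=O)c1=O)c1ccc(C)s1`: 146 nM
Compound 2, `CCCCc1coc([C@@H](CC)Nc2c(Nc3cccc(C(=O)N(C)C)c3O)c(=O)c2=O)c1`: 34 nM

In an assay on CHO cells for displacement of a labelled ligand from C-X-C chemokine receptor type 1 (Homo sapiens) (a lower number here means a stronger inhibitor, a higher number a weaker inhibitor), compound 1 gives 146 nM, while compound 2 gives 34 nM. Among the compounds with values here, the one measured step, a 4.3-fold lower number from compound 1 to compound 2 (0.63 log units; beyond the scatter), replaces the whole ring on the chain carbon bound to the nitrogen. Within the data shown here, compound 2 therefore holds the lowest number of the two, with compound 1 the only neighbour and clearly higher.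

Compound 3, `CCC(C)c1coc([C@@H](CC)Nc2c(Nc3cccc(C(=O)N(C)C)c3O)c(=O)c2=O)c1`, keeps everything of compound 2 except the substituent on the furan ring: sec-butyl in place of butyl on an aromatic carbon. Among the measured compounds shown here, no measured step touches this substituent; the step from compound 1 to compound 2 exchanged the ring itself, not the chain on it, so it gives no direct guide. A rearrangement of the same four carbons is expected to leave the number close to that of compound 2, with the estimated step of a 1.2-fold higher number from compound 2 to compound 3 (0.07 log units; within the scatter) not beyond the scatter. Compound 3 is thus estimated at 40 nM, within a range from 15 nM to 110 nM.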

Compound 3, inhibition constant: 7.6 nM
Compound 3: the middle estimate sits 5.3-fold (0.72 log units) above what was measured, and the stated range ends above it.
By their numbers in this assay, from the lowest: compound 3; then compound 2; then compound 1.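

In this assay, the furan substituent matters even with the same atoms: exchanging butyl for sec-butyl on this aromatic carbon, two ring bonds from the ring oxygen, gives a 4.5-fold lower number from compound 2 to compound 3 (0.65 log units; beyond the scatter). Taken as a single exchange on the saturated chain carbon, replacing 5-methylthiophen-2-yl with 4-(sec-butyl)furan-2-yl gives a 19-fold lower number from compound 1 to compound 3 (1.28 log units; beyond the scatter), leaving compound 3 with the lowest number of the three. No evidence is available that explains why the branched chain gives the lower number.

The compounds shown leave open whether a shorter branched group such as isopropyl, or a more heavily branched one such as tert-butyl, would carry the same gain at this position. They also leave open whether sec-butyl would give a similar step on the 5-methylthiophen-2-yl ring in place of its methyl.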